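This account rests on a few compounds, and the source may have more. Where it says the series, first, only, none or still open, it means among the compounds named here.

In a functional assay on MCF7 cells (Homo sapiens) for inhibition, read by sulforhodamine B assay, with a stated time of 48 h, tested at 50 uM (on this read-out lower numbers stand for less inhibition of growth and higher numbers for more inhibition of growth at the one concentration tested), compound 2 (`COc1ccc([C@@H]2C/C(=N/OCc3cn(-c4cccc(CO)c4)nn3)c3cc(CC=C(C)C)c(OC)cc3O2)cc1`) gives 42% and compound 1 (`COc1ccc([C@@H]2C/C(=N/OCc3cn(-c4ccc(Cl)cc4C)nn3)c3cc(CC=C(C)C)c(OC)cc3O2)cc1`) gives 37% so that the two numbers lie within the scatter of each other. Compound 3 (`COc1ccc([C@@H]2C/C(=N/OCc3cn(-c4ccccc4CO)nn3)c3cc(CC=C(C)C)c(OC)cc3O2)cc1`) differs from compound 2 at one place (2-(hydroxymethyl)phenyl in place of 3-(hydroxymethyl)phenyl on an aromatic nitrogen) with 2-(hydroxymethyl)phenyl in place of 3-(hydroxymethyl)phenyl on an aromatic nitrogen. Among the measured compounds shown here, the only measured step at that nitrogen is a number 5 percentage points higher from compound 1 to compound 2 (within the scatter) and it exchanged 4-chloro-2-methylphenyl for 3-(hydroxymethyl)phenyl. For the measured compounds named here, no measured compound carries the 2-(hydroxymethyl)phenyl group, so the evidence is thin. With that single small step as the guide, no step beyond the scatter is expected in this assay in either direction. The estimated step is a number 2 percentage points lower from compound 2 to compound 3 (within the scatter) and it stays within the scatter. Compound 3 is expected at 40% with an estimated range from 25% to 55% for repeated measurements.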

Compound 3, percent growth inhibition at one concentration: 100%
For compound 3 the middle estimate is 60 percentage points below the measured one, outside the stated range (above it).
By their numbers in this assay, from the lowest: compounds 1 and 2 (each within the scatter of the next); then compound 3.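

At this nitrogen the aryl group is not as forgiving as the earlier pair suggested: in this assay, 2-(hydroxymethyl)phenyl in place of 3-(hydroxymethyl)phenyl gives a number 58 percentage points higher from compound 2 to compound 3 (beyond the scatter), although the two groups have the same atoms, joined differently. So where the hydroxymethyl group sits on the phenyl ring decides the result here, and 2-(hydroxymethyl)phenyl in place of 4-chloro-2-methylphenyl gives a number 63 percentage points higher from compound 1 to compound 3 (beyond the scatter), which sets compound 3 clearly apart from both earlier compounds. Nothing at hand explains why this one change has so large an effect.

The compounds shown leave open whether the hydroxyl itself is needed, which a 2-methylphenyl, 2-(aminomethyl)phenyl or 2-carboxyphenyl group on the same nitrogen would address. They also leave open whether a longer chain, such as 2-(2-hydroxyethyl)phenyl, would hold the effect, and how compound 3 behaves at concentrations other than the single one tested.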